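This account rests on a few compounds, and the source may have more. Where it says the series, first, only, none or still open, it means among the compounds named here.

Series notes, chain-length variation on the ester end of the shared core, read in a functional assay on A549 cells (Homo sapiens) for cytotoxicity, read by MTT assay, with a stated time of 24 h, tested at 80 uM; a lower number here means a stronger effect, a higher number a weaker effect of the compound at the concentration tested.

Compound 1 `CCCCCOC(=O)CCC(=O)N1CCN(CCCOc2cc3c(Nc4ccc(F)c(Cl)c4)ncnc3cc2OC)CC1` gives 18.2%. Compound 2 `CCCCCCOC(=O)CCC(=O)N1CCN(CCCOc2cc3c(Nc4ccc(F)c(Cl)c4)ncnc3cc2OC)CC1` gives 42.9%; the step is a number 24.7 percentage points higher from compound 1 to compound 2 (beyond the scatter). Compound 3 `CCCCCCCCCCOC(=O)CCC(=O)N1CCN(CCCOc2cc3c(Nc4ccc(F)c(Cl)c4)ncnc3cc2OC)CC1` gives 2%, the lowest of the three, with a number 16.2 percentage points lower from compound 1 to compound 3 (beyond the scatter) and a number 40.9 percentage points lower from compound 2 to compound 3 (beyond the scatter).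

Compound 4 `CCCCCCCCCCCOC(=O)CCC(=O)N1CCN(CCCOc2cc3c(Nc4ccc(F)c(Cl)c4)ncnc3cc2OC)CC1` is not yet measured. It differs from compound 3 by methyl in place of hydrogen on a saturated chain carbon, ten or more bonds along the chain from an oxygen next to a carbonyl group. The same change from compound 1 to compound 2, (methyl in place of hydrogen on a saturated chain carbon, five bonds along the chain from an oxygen next to a carbonyl group), made a step of a number 24.7 percentage points higher from compound 1 to compound 2 (beyond the scatter). The two cores differ by pentyl in place of hydrogen on a saturated chain carbon, five bonds along the chain from an oxygen next to a carbonyl group, and the place of the change is not identical in the two pairs, as the two differences just given show, so this is the same kind of change rather than the same change.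

A small step is expected, a number 4 percentage points higher from compound 3 to compound 4 (within the scatter), because compound 3 already sits at 2% and the longer-chain series ran downward in a number 40.9 percentage points lower from compound 2 to compound 3 (beyond the scatter). Compound 4 is estimated at 6%, between 1% and 25%.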

Compound 4, a percentage reported as activity, at one concentration (the size of the read-out at that concentration, not a potency): 2.8%
Compound 4: the middle estimate sits 3.2 percentage points above what was measured; the range from low to high includes it.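

Adding methyl to the chain of compound 3, a step of a number 0.8 percentage points higher from compound 3 to compound 4 (within the scatter) in this assay, does not repeat the step seen on the shorter chain: the same change on two cores in this assay, a number 24.7 percentage points higher (beyond the scatter) from compound 1 to compound 2 and a number 0.8 percentage points higher (within the scatter) from compound 3 to compound 4, 23.9 percentage points apart, beyond the scatter of two such steps

The pentyl change also gives different steps on different cores: the same change on two cores in this assay, a number 16.2 percentage points lower (beyond the scatter) from compound 1 to compound 3 and a number 40.1 percentage points lower (beyond the scatter) from compound 2 to compound 4, 23.9 percentage points apart, beyond the scatter of two such steps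

The steps of a number 40.1 percentage points lower from compound 2 to compound 4 (beyond the scatter) and a number 15.4 percentage points lower from compound 1 to compound 4 (beyond the scatter) place compound 4 well under both shorter-chain compounds, so the size of a chain extension does not carry over between cores here, but four compounds do not show why, nor whether compound 2 is an isolated exception.

Still open, going by these compounds, is how the read-out runs at chain lengths between those of compound 2 and compound 3, or with a longer chain than that of compound 4. On these data alone, a branched chain, or an amine or carboxylic acid at the chain end, also remains open.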